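Working notes: from compound 2 to compound 4

A few compounds are considered here, and "the series" means these few. Any claim that something is new, unique, unknown or untested is made for them only; others in the source may bear on it.

Of the compounds shown here, three have been measured in a functional assay on MDA-MB-468 cells (Homo sapiens) for cytotoxicity, read by resazurin assay, with a stated time of 72 h; on this read-out higher numbers stand for weaker inhibition and lower numbers for stronger inhibition. Compound 1 `S=C(NCc1cccnc1)SCCn1nc2ccccc2n1` gives 11600 nM. Compound 2 `S=C(NCc1cccnc1)SCCc1nnc(-c2ccc(Cl)cc2)o1` gives 1980 nM, and compound 3 `S=C(NCc1cccnc1)SCCc1nnc(-c2ccc3ncccc3c2)o1` gives 1690 nM. Compound 2 stands second highest of the three numbers; its nearest neighbour is compound 3, whose number lies within the scatter of its own, and its furthest is compound 1, whose higher number lies well beyond the scatter.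

Compound 4 `S=C(NCc1cccnc1)SCCc1nnc(-c2cc3ccccc3s2)o1` has not yet been measured. It differs from compound 2 in one place: 1-benzothiophen-2-yl in place of 4-chlorophenyl on an aromatic carbon. For the measured compounds named here, no pair of measured compounds differing in one place is available, so the size of this kind of step cannot be read from the data. Compound 3 also carries a larger group on the shared core, and its number sits within the scatter of that of compound 2, which suggests little movement. The step from compound 2 to compound 4 in this assay is therefore expected to be small, a 1.3-fold lower number from compound 2 to compound 4 (0.12 log units; within the scatter), not beyond the scatter, if anything toward a lower number. Compound 4 is expected to give 1500 nM in this assay, with a range from 600 nM to 4000 nM.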

Compound 4, half-maximal inhibitory concentration: 6770 nM
Compound 4: the middle estimate sits 4.5-fold (0.65 log units) below what was measured; measured number outside the range, above it.
By their numbers in this assay, from the lowest: compounds 3 and 2 (each within the scatter of the next); then compounds 4 and 1 (each within the scatter of the next).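

In this assay, the position on the aromatic carbon next to the ring nitrogen and the ring oxygen proves sensitive to the group it carries: 1-benzothiophen-2-yl in place of 4-chlorophenyl gives a 3.4-fold higher number from compound 2 to compound 4 (0.53 log units; beyond the scatter), the first step read at this place. A larger group alone does not settle the outcome, since compound 3, which also carries a larger group on the shared core, gives 1690 nM, whereas compound 4 gives 6770 nM in the same read-out. Nothing at hand explains this change.

Still open, from the compounds shown here alone, is how an unsubstituted phenyl or a small methyl group would behave at this carbon. Also open, going by these compounds, is whether a dimethylamino group on the phenyl ring would hold the number of compound 2 or shift it.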